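Extending the alkoxy chain: from butoxy to heptyloxy

The source may hold more compounds than are shown below. What is called first, only, known or untested is meant among the compounds shown, and "the series" means these compounds.

Measured so far in a functional assay on brain (Rattus norvegicus, strain Wistar) for inhibition; a higher number here means a weaker inhibitor, a lower number a stronger inhibitor:
compound 1 `CCCCOc1ccc(-c2c(C)[nH]c(=O)n2C2CCCCC2)cc1`, 13900 nM;
compound 2 `Cc1ccc(-c2c(C)[nH]c(=O)n2C)cc1`, 85300 nM;
compound 3 `Cc1[nH]c(=O)n(C)c1-c1ccc(Oc2ccccc2)cc1`, 8100 nM.

Among these three numbers compound 1 stands second highest. Its nearest neighbour is compound 3, whose value of 8100 nM differs from that of compound 1 only within the scatter. Its furthest neighbour is compound 2, whose value of 85300 nM lies clearly above, beyond the scatter.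

Compound 4 `CCCCCCCOc1ccc(-c2c(C)[nH]c(=O)n2C2CCCCC2)cc1` arises from compound 1 by a single change: propyl in place of hydrogen on a saturated chain carbon, four bonds along the chain from an oxygen on an aromatic ring.

Going by the values given here, only one step between measured compounds is recorded, an 11-fold lower number from compound 2 to compound 3 (1.02 log units; beyond the scatter), and it concerns the group on the aromatic carbon, not the length of an alkoxy chain. Among the compounds with values here, no measured pair shows what lengthening such a chain does. Within the data shown here, the comparison of compound 1 with compound 3, which is within the scatter, is the only hint that changes at this end of the molecule may matter little, so no step beyond the scatter is expected for compound 4 in this assay.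

The estimate for compound 4 is 10000 nM, with a range of 3500 nM to 35000 nM, which is expected to mean a 1.4-fold lower number from compound 1 to compound 4 (0.14 log units; within the scatter).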

Compound 4, half-maximal inhibitory concentration: 11600 nM
Compound 4: the middle estimate sits 1.2-fold (0.06 log units) below what was measured; low and high end bracket the measured number.
By their numbers in this assay, from the lowest: compounds 3, 4 and 1 (each within the scatter of the next); then compound 2.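

Going by these compounds alone, compound 1 and compound 4 form the first measured pair that differ only in the length of the alkoxy chain, and in this assay the propyl in place of hydrogen gives a 1.2-fold lower number from compound 1 to compound 4 (0.08 log units; within the scatter). Butoxy and heptyloxy therefore cannot be told apart at this position, so adding propyl on this saturated chain carbon, four bonds along the chain from an oxygen on an aromatic ring, has no readable effect in this pair, unlike the change on the aromatic carbon, which gave an 11-fold lower number from compound 2 to compound 3 (1.02 log units; beyond the scatter) on a different set of substituents. Nothing available gives a reason for this flat result.

The two chain lengths shown say nothing about whether a methoxy or ethoxy group, or a chain longer than heptyloxy such as decyloxy, would stay within the scatter of compound 1 on the same core. Going by these compounds, it also remains open whether an amine or a carboxylic acid at the end of the chain, or a phenoxy group in place of the butoxy group of compound 1, would move the number beyond the scatter.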